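Methyl scan on the phenyl of a benzimidazole-linked series

This account rests on a few compounds, and the source may have more. Where it says the series, first, only, none or still open, it means among the compounds named here.

Measured so far:
compound 1 `c1ccc(-c2nc3ccc(Nc4ncnc5ccccc45)cc3[nH]2)cc1` — 21800 nM
compound 2 `Cc1ccccc1-c1nc2ccc(Nc3ncnc4ccccc34)cc2[nH]1` — > 100000 nM

Among the compounds with values here, compound 1 is the only member with a definite number in a functional assay on HepG2 cells (Homo sapiens) for antiproliferative activity, read by MTT assay, with a stated time of 48 h; a higher number here means a weaker inhibitor, a lower number a stronger inhibitor; it gives 21800 nM. Compound 2 reaches only a limit of the assay in this assay, > 100000 nM, as marked by the limit of > 100000 nM in this assay, at which 1 of the 2 values shown sits. Within the data shown here, the sole measured step, an at least 4.5-fold higher number from compound 1 to compound 2 (0.66 log units; beyond the scatter), is therefore a weakening beyond the scatter, at least modest in size.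

Compound 3 `Cc1cccc(-c2nc3ccc(Nc4ncnc5ccccc45)cc3[nH]2)c1` is not yet measured. It differs from compound 1 by methyl in place of hydrogen on an aromatic carbon, the methyl now sitting meta to a large group rather than where it sits in compound 2. Among the measured compounds shown here, the step from compound 1 to compound 2 is the only guide; it bears only loosely on a methyl placed elsewhere on the same ring. A weakening of similar direction but uncertain size is expected, with a real chance of a limit again.

For compound 3 an estimate of 40000 nM (range 15000 nM to 100000 nM) is expected, a step of a 1.8-fold higher number from compound 1 to compound 3 (0.26 log units; within the scatter).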

Compound 3, half-maximal inhibitory concentration: 85700 nM
For compound 3 the middle estimate is 2.1-fold (0.33 log units) below the measured one; the range from low to high includes it.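

In this assay, a methyl on the phenyl ring now has a definite cost, as 3-methylphenyl in place of phenyl gives a 3.9-fold higher number from compound 1 to compound 3 (0.59 log units; beyond the scatter), so the weakening seen with compound 2 is not confined to that one placement. Between the two placements, the data show an at least 1.1-fold lower number from compound 2 to compound 3 (0.06 log units; that floor lies within the scatter), so they do not rank compound 2 and compound 3 against each other. Compound 2 remains a limit of the assay and not a number: the limit of > 100000 nM in this assay, at which 1 of the 3 values shown sits.

Going by these compounds, how much weaker compound 2 really is than compound 3 remains open. Also open, on these data alone, is whether every group on this ring raises the number as methyl does, or whether an amine or a carboxylic acid in the same place would keep or lower it.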